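Fluoro for Methoxy on a Fused Pyridone Core

This account rests on a few compounds, and the source may have more. Where it says the series, first, only, none or still open, it means among the compounds named here.

Three compounds in this series share a para-methoxybenzyl group joined through a urea or thiourea to a piperidine, which in turn carries an ethyl chain into a bicyclic core. Compound 1 `COc1ccc(CNC(=O)NC2CCN(CCn3c(=O)ccc4ncc(OC)cc43)CC2)cc1` bears a urea and a methoxy group on that core; compound 2 `COc1ccc(CNC(=S)NC2CCN(CCn3c(=O)ccc4ncc(F)cc43)CC2)cc1` bears a thiourea and a fluoro group; compound 3 `COc1ccc(CNC(=S)NC2CCN(CCn3c(=O)ccc4ncc(OC)cc43)CC2)cc1` bears a thiourea and a methoxy group. The difference between the core of compound 1 and that of compound 3 is not broken down here.

In an ADME assay on RAW264.7 cells (Mus musculus) for cytotoxicity, read by MTT assay, with a stated time of 48 h, tested at 100 uM (on this read-out lower numbers stand for less inhibition and higher numbers for more inhibition at the one concentration tested (going by the name of the read-out)), compound 3 gives 19.4%, compound 2 gives 41.3% and compound 1 gives 39.5%. The change from compound 3 to compound 2, (fluoro in place of methoxy on an aromatic carbon), produced a step of a number 21.9 percentage points higher from compound 3 to compound 2 (beyond the scatter). Compound 1 and compound 2 lie within the scatter of one another, while compound 1 stands well apart from compound 3.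

The not yet measured compound 4 `COc1ccc(CNC(=O)NC2CCN(CCn3c(=O)ccc4ncc(F)cc43)CC2)cc1` relates to compound 1 by the same change, (fluoro in place of methoxy on an aromatic carbon), at the same place. Because the step of a number 21.9 percentage points higher from compound 3 to compound 2 (beyond the scatter) was modest but beyond the scatter, the account expects a step of comparable size, estimated as a number 16.5 percentage points higher from compound 1 to compound 4 (beyond the scatter), from compound 1 to compound 4. On this basis compound 4 is estimated to give about 56% in this assay, with a range expected from 38% to 74%.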

Compound 4, a percentage reported as inhibition, at one concentration (the size of the read-out at that concentration, not a potency): 32.1%
The estimate for compound 4 lay 23.9 percentage points above the measured number; the measured number lies below the stated range.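

In this assay, fluoro in place of methoxy on the urea compounds gives a number 7.4 percentage points lower from compound 1 to compound 4 (within the scatter), so the clear step seen with the thioureas does not reappear here and this change cannot be carried from one core to the other as a fixed increment. The two steps themselves differ, which makes the result of the change depend on the compound that receives it in this small set: the same change on two cores in this assay, a number 21.9 percentage points higher (beyond the scatter) from compound 3 to compound 2 and a number 7.4 percentage points lower (within the scatter) from compound 1 to compound 4, 29.3 percentage points apart, beyond the scatter of two such steps This rests on just two matched pairs at a single concentration, so it does not show what lies behind the difference, nor does it show how the change would behave on any other core in the series.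

The compounds shown leave open whether other groups on that same aromatic carbon, such as chloro, a nitrile or an amine, would follow the thiourea pair, the urea pair or neither. They also leave open whether the two steps would stay apart if the ethyl chain gave way to a longer chain, or if the methoxy group on the benzyl ring gave way to a carboxylic acid.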